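This account rests on a few compounds, and the source may have more. Where it says the series, first, only, none or still open, it means among the compounds named here.

Four compounds share one core, differing in the group on a saturated ring carbon of a three-membered ring and in the amine-bearing side chain. Compound 1 `CO[C@H](C)[C@H](N)CN(C(=O)[C@@H]1C[C@H]1c1ccccc1)c1ccc(-c2ccccc2)cc1` gives 0.68 nM in a functional assay for agonist activity at G protein-coupled receptor 88 (Homo sapiens), read by HTRF and cAMP accumulation; on this read-out higher numbers stand for an effect only at larger amounts of compound and lower numbers for an effect already at smaller amounts. Compound 2 `O=C([C@@H]1C[C@H]1c1ccccc1)N(CC1CCCNC1)c1ccc(-c2ccccc2)cc1` gives 10 nM in this assay, which is a 15-fold higher number from compound 1 to compound 2 (1.17 log units; beyond the scatter). Compound 3 `CC[C@H](C)[C@H](N)CN(C(=O)[C@@H]1C[C@H]1C1CCCCC1)c1ccc(-c2ccccc2)cc1` carries a cyclohexyl on the three-membered ring and a different side chain; for compound 3 this assay reports only a limit, > 25000 nM, so compound 3 stands at the limit of > 25000 nM in this assay, at which 1 of the 3 values shown sits, and no number is known for it. Compound 4 `CC[C@H](C)[C@H](N)CN(C(=O)[C@@H]1C[C@H]1c1ccsc1)c1ccc(-c2ccccc2)cc1` differs from compound 3 by thiophen-3-yl in place of cyclohexyl on a saturated ring carbon. For the measured compounds named here, no measured step covers this change, and the only measured step, from compound 1 to compound 2, concerns the side chain instead. Compound 1 bears a phenyl where compound 3 bears a cyclohexyl, yet the two also differ in the side chain, so their values cannot be read as one step. With only a limit for compound 3, the expected step of an at least 830-fold lower number from compound 3 to compound 4 (2.92 log units; beyond the scatter) is uncertain in size. Compound 4 is estimated at 30 nM, within 2 nM to 5000 nM.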

Compound 4, half-maximal effective concentration: 450 nM
For compound 4 the middle estimate is 15-fold (1.18 log units) below the measured one, within the range that was stated.
By their numbers in this assay, from the lowest: compound 1; then compound 2; then compound 4. At a limit, above all of these: compound 3.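

On the saturated ring carbon of the three-membered ring, with the side chain unchanged, thiophen-3-yl in place of cyclohexyl gives an at least 55-fold lower number from compound 3 to compound 4 (1.74 log units; beyond the scatter) in this assay. For the compounds shown here, this is the only measured step at this position, and it shows that the group here matters on its own, apart from the side chain changed in the step from compound 1 to compound 2. The full size of the step stays unknown, as compound 3 gives a limit and not a number: the limit of > 25000 nM in this assay, at which 1 of the 4 values shown sits.

The change swaps a six-membered non-aromatic ring of carbon only for a five-membered aromatic ring holding sulfur, so these compounds cannot say which of those differences counts. Cyclopentyl or phenyl on the side chain of compound 4 would leave open fewer of these differences, and how either would compare with thiophen-3-yl remains unknown.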